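A few compounds are considered here, and "the series" means these few. Any claim that something is new, unique, unknown or untested is made for them only; others in the source may bear on it.

Compound 1, `CCOc1ccccc1N1CCN(CCCNc2ncccc2C(=O)N(C)C)CC1` — in a functional assay for antagonist activity at Alpha-1A adrenergic receptor (Oryctolagus cuniculus) (on this read-out lower numbers stand for tighter binding and higher numbers for weaker binding), compound 1 gives 0.501 nM.
Compound 2, `CN(C)C(=O)c1cccnc1NCCCN1CCN(c2ccccc2C2CC2)CC1` — compound 2 gives 0.631 nM.
Compound 3, `CN(C)C(=O)c1cccnc1NCCCN1CCN(c2ccccc2C(F)(F)F)CC1` — compound 3 gives 12.6 nM.

Among these three, compound 3 carries the highest number in this assay. Its nearest neighbour is reached by the step of a 20-fold higher number from compound 2 to compound 3 (1.30 log units; beyond the scatter), the more distant one by a 25-fold higher number from compound 1 to compound 3 (1.40 log units; beyond the scatter); both steps lie well beyond the scatter, and both brought a trifluoromethyl onto the same aromatic carbon. The step of a 1.3-fold higher number from compound 1 to compound 2 (0.10 log units; within the scatter) between the other two stays within the scatter.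

Compound 4, `COc1cc(O)ccc1N1CCN(CCCNc2ncccc2C(=O)N(C)C)CC1`, differs from compound 3 by 4-hydroxy-2-methoxyphenyl in place of 2-(trifluoromethyl)phenyl on an amine nitrogen in a ring. The entering group carries a methoxy where compound 1 carried its ethoxy, and compound 1 gave the low number 0.501 nM. The two steps that bear on the change run toward compound 3, and compound 4 walks away from it again, so a large fall in the number is expected, because a 25-fold higher number from compound 1 to compound 3 (1.40 log units; beyond the scatter) and a 20-fold higher number from compound 2 to compound 3 (1.30 log units; beyond the scatter) were both large. Among the measured compounds shown here, the added hydroxy has no measured counterpart here, which widens the range. Compound 4 is expected to give 1 nM, between 0.3 nM and 5 nM. That estimate means an expected step of a 13-fold lower number from compound 3 to compound 4 (1.10 log units; beyond the scatter).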

Compound 4, dissociation constant: 12.6 nM
Beside the measured number, compound 4's estimate is 13-fold (1.10 log units) below it, outside the stated range (above it).
By their numbers in this assay, from the lowest: compounds 1 and 2 (each within the scatter of the next); then compounds 3 and 4 (each within the scatter of the next).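

In this assay, 4-hydroxy-2-methoxyphenyl on the amine nitrogen in a ring does not keep the low numbers seen with 2-ethoxyphenyl and 2-cyclopropylphenyl, giving a 25-fold higher number from compound 1 to compound 4 (1.40 log units; beyond the scatter) and a 20-fold higher number from compound 2 to compound 4 (1.30 log units; beyond the scatter). Against 2-(trifluoromethyl)phenyl the record shows no change at the digits printed from compound 3 to compound 4 (within the scatter), so a group with a hydrogen-bond donor and acceptors reads alike with one that has neither. Nothing available here accounts for this result.

Still open, on these data alone, is whether the hydroxy or the methoxy carries the large steps from the two low-number compounds. The same group with its methoxy replaced by ethoxy, or with its hydroxy replaced by an amine or a hydrogen, would bear on that question.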